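The source may report more compounds than this note shows. Statements on the series, on what has been measured and on what is new or still open speak of the compounds shown alone.

Measured in an ADME assay on microsomes from liver (Homo sapiens) for metabolic stability, with a stated time of 10 min; on this read-out higher numbers stand for a more stable compound and lower numbers for a less stable compound:
compound 1 `O=C(O)C1CCC(O)(C(=O)N2CC[C@](c3ccc(C(F)(C(F)(F)F)C(F)(F)F)cc3)(S(=O)(=O)c3ccc(F)cc3)C2)CC1`: 100%; 95% (2 entries)
compound 2 `COC(=O)[C@H]1CC[C@H](C(=O)N2CC[C@](c3ccc(C(F)(C(F)(F)F)C(F)(F)F)cc3)(S(=O)(=O)c3ccc(F)cc3)C2)CC1`: "not determined" (no result reported)

Compound 2 has no single number on this read-out, and its one entry reports no result, so its standing cannot be fixed. The only figures in the series are the several entries of compound 1 in this assay, 100%; 95% (2 entries), and they agree within the usual scatter.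

Compound 3 `O=C([C@H]1CC[C@H](CO)CC1)N1CC[C@](c2ccc(C(F)(C(F)(F)F)C(F)(F)F)cc2)(S(=O)(=O)c2ccc(F)cc2)C1` is still to be measured in this assay. The structural change is hydroxymethyl in place of methoxycarbonyl on a saturated ring carbon, three ring bonds from the ring atom that bears a large group.

Among the measured compounds shown here, no measured step starts from compound 2, so the size of this one cannot be read from the data. The working expectation is that it brings no change beyond the scatter, with any departure more likely downward, since compound 1 at 100%; 95% (2 entries) already sits near the top of the scale. For the measured compounds named here, that anchor is thin, as compound 1 is the only compound with numbers on the shared core.

For compound 3 the expected value is 88%, with an estimated range of 65% to 100%.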

Compound 3, percent of the compound remaining: 75%
The estimate for compound 3 lay 13 percentage points above the measured number; the measured number falls inside the stated range.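

In this assay, among the compounds shown here, compound 3 gives 75%, but compound 2 has no single number there, so no step from compound 2 to compound 3 can be read. The compounds shown leave open how far hydroxymethyl in place of methoxycarbonyl on the saturated ring carbon shifts the result in this assay.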